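Replacing chloro with nitro in a cytotoxicity series

The compounds below may be only part of what the source reports. "The series", "measured", "known", "first", "only" and "open" are said of these compounds alone.

Compound 1 `FC(F)(F)c1cccc(NC(=S)Nc2ccc(I)cc2)c1` - 9500 nM
Compound 2 `FC(F)(F)c1cccc(NC(=S)Nc2ccc(Cl)cc2)c1` - 17000 nM

In an ADME assay on MDBK cells (Bos taurus) for cytotoxicity, read by MTT assay, with a stated time of 96 h (on this read-out lower numbers stand for higher toxicity in this test and higher numbers for lower toxicity in this test), compound 2 gives 17000 nM and so lies within the scatter of compound 1 at 9500 nM in the same test. Compound 3 `O=[N+]([O-])c1ccc(NC(=S)Nc2cccc(C(F)(F)F)c2)cc1` has not yet been measured. The change from compound 2 is nitro in place of chloro on an aromatic carbon and amounts to nitro in place of chloro on an aromatic carbon, para to a large group. Going by the values given here, the one measured step that bears on it is a 1.8-fold higher number from compound 1 to compound 2 (0.25 log units; within the scatter) and it puts chloro in place of iodo, so no step beyond the scatter is expected in this assay and no firm direction can be given. Among the compounds with values here, no measured compound carries nitro, and this keeps the range wide. The estimated step is a 1.1-fold lower number from compound 2 to compound 3 (0.05 log units; within the scatter) and it remains only an expectation. For compound 3 the expected value is 15000 nM with an estimated range of 6000 nM to 40000 nM for now.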

Compound 3, half-maximal cytotoxic concentration: 10000 nM
Estimate against measurement, compound 3: 1.5-fold (0.18 log units) above; low and high end bracket the measured number.
By their numbers in this assay, from the lowest: compounds 1, 3 and 2 (each within the scatter of the next).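

In this assay, the aromatic carbon para to a large group now carries a nitro group as well as the two halogens, and the new steps are a 1.7-fold lower number from compound 2 to compound 3 (0.23 log units; within the scatter) and a 1.1-fold higher number from compound 1 to compound 3 (0.02 log units; within the scatter). The earlier compounds shown here compared only chloro with iodo, whereas compound 3 replaces the single heavy atom of chloro, which has no hydrogen-bond acceptors, with the three heavy atoms and two hydrogen-bond acceptors of nitro, yet all three compounds remain within the scatter of one another in this test. So a change in this place that alters these counts, and not just one halogen for another, still gives no readable difference here, and no measurement at hand offers an explanation for this result.

As far as these compounds go, whether an amine or a carboxylic acid on this aromatic carbon would give a step beyond the scatter remains open. From the compounds shown here alone, it is also open whether nitro in place of chloro would still give so small a step if a methoxy group stood in place of the trifluoromethyl group elsewhere on the shared core.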